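The compounds below may be only part of what the source reports. "The series", "measured", "known", "first", "only" and "open" are said of these compounds alone.

Measured so far:
compound 1 `Cc1nc(SCC(=O)Nc2nc(-c3ccc(Cl)cc3)cs2)n(Nc2ccccc2)c1C` — in a functional assay on DU-145 cells (Homo sapiens) for antiproliferative activity, read by sulforhodamine B assay, with a stated time of 48 h (on this read-out higher numbers stand for weaker inhibition of growth and lower numbers for stronger inhibition of growth), compound 1 gives 18700 nM
compound 2 `Cc1ccc(Nn2c(SCC(=O)Nc3nc(-c4ccccc4)cs3)nc(C)c2C)cc1` — in this assay compound 2 gives 64600 nM

Of the two numbers, compound 1 holds the lower one; compound 2 sits a good way higher, beyond the usual scatter. The two differ in two places. Within the data shown here, no single-point step connects them, and their gap is taken only as what the two values show.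

Compound 3, `COc1ccc(Nn2c(SCC(=O)Nc3nc(-c4ccc(Cl)cc4)cs3)nc(C)c2C)cc1`, has not yet been measured. It differs from compound 1 by methoxy in place of hydrogen on an aromatic carbon. Among the measured compounds shown here, no single-point step between measured compounds is available to calibrate this change, so the expectation rests on the two values alone. Compound 2, which also carries a substituent on that six-membered ring, is weaker, but it also lacks the chloro group, so its number carries little weight here. For compound 3 a step of about a 1.3-fold higher number from compound 1 to compound 3 (0.13 log units; within the scatter) is expected, small and within scatter. Compound 3 is estimated at 25000 nM, with a range from 9000 nM to 70000 nM.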

Compound 3, concentration for total growth inhibition: > 100000 nM
Compound 3: only a limit was reported; the forecaster's own chance of this, stated with the estimate: 10%; middle value at least 4.0-fold (0.60 log units) from the limit.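

In this assay compound 3 gives > 100000 nM, which is a limit of the assay and not a number. Methoxy in place of hydrogen on an aromatic carbon, para to a large group, gives an at least 5.3-fold higher number from compound 1 to compound 3 (0.72 log units; beyond the scatter), so this position of the anilino ring does not take the change without a loss of growth inhibition, and this is the first single-point step available in the set. The true size of that step stays unknown, and only this one compound reaches the limit: the limit of > 100000 nM in this assay, at which 1 of the 3 values shown sits.

A single step cannot tell whether the loss belongs to methoxy itself or would follow any group placed there, such as fluoro, hydroxyl or an amine. On these data alone, whether methoxy elsewhere on this ring would do the same also remains open.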